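The source may hold more compounds than are shown below. What is called first, only, known or untested is meant among the compounds shown, and "the series" means these compounds.

Compound 2 is `CC(=O)c1cccc(-c2ccc(C(=O)N(Cc3cccc(OCCCCCC(=O)O)c3)C(C)C)cc2)c1`. In an ADME assay on BJ cells (Homo sapiens) for cytotoxicity, read by CellTiter-Glo and resazurin assay, with a stated time of 72 h (on this read-out lower numbers stand for an effect already at smaller amounts and higher numbers for an effect only at larger amounts of compound), compound 2 gives > 26000 nM, which is a limit of the assay and not a measured number. Compound 1, `CC(C)N(Cc1cccc(OCCCCCC(=O)O)c1)C(=O)c1ccc(-c2cccc(N(C)C)c2)cc1`, differs from it in a single place, acetyl in place of dimethylamino on an aromatic carbon. In this assay compound 1 gives > 26000 nM, again only a limit. The step that the two limits leave unreadable from compound 1 to compound 2 therefore cannot be read in either direction. What the numbers do show is the limit of > 26000 nM in this assay, at which 2 of the 2 values shown sit.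

Compound 3 is `CC(C)N(Cc1cccc(OCCCCCC(=O)O)c1)C(=O)c1ccc(-c2ccc3[nH]ccc3c2)cc1`. It differs from compound 2 by 1H-indol-5-yl in place of 3-acetylphenyl on an aromatic carbon. Among the compounds with values here, no measured pair carries this change, and the single measured step in the set is unreadable, so the numbers give no lead on direction or size. The step that the limit leaves unreadable from compound 2 to compound 3 is expected to stay within the scatter, given (the limit of > 26000 nM in this assay, at which 2 of the 2 values shown sit), with a strong chance that this assay again reports only a limit. Compound 3 is therefore estimated to give 30000 nM, in a range from 10000 nM to 100000 nM.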

Compound 3, half-maximal effective concentration: > 26000 nM
Compound 3 gave a limit, no number; the forecaster's own chance of this, stated with the estimate: 80%; the middle value does not contradict the limit.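

Compound 3, like compound 1 and compound 2, gives only a limit of the assay and no number, so no step among these three compounds can be read, and what stands is this: the limit of > 26000 nM in this assay, at which 3 of the 3 values shown sit. The compounds shown leave open whether any change at this place on the shared core would give a measured number in this assay.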